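Ester to amide and amine side-chain swap in a GnRH series

The compounds below may be only part of what the source reports. "The series", "measured", "known", "first", "only" and "open" are said of these compounds alone.

Measured compounds in an assay on HEK293 cells for binding affinity to Gonadotropin-releasing hormone receptor (Homo sapiens), read by radioligand binding; a higher number here means a weaker inhibitor, a lower number a stronger inhibitor:
compound 1, `CCCC(=O)Nc1ccc(-c2cc3n(Cc4ccccc4F)cc(C(=O)OC(CC)CC)c(=O)n3c2CN(C)Cc2ccccc2)cc1`, 3.8 nM
compound 2, `CCCCNC(=O)c1cn(Cc2ccccc2F)c2cc(-c3ccc(NC(=O)CCC)cc3)c(CN(C)Cc3ccccc3)n2c1=O`, 154 nM

Compound 2 gives the highest number of the two; a 41-fold higher number from compound 1 to compound 2 (1.61 log units; beyond the scatter). Compound 3, `CCCCNC(=O)c1cn(Cc2ccccc2F)c2cc(-c3ccc(NC(=O)CCC)cc3)c(CN(C)CCN(CC)CC)n2c1=O`, keeps the butylamide of compound 2 and changes the amine side chain: (diethylamino)methyl in place of phenyl on a saturated chain carbon bound to an amine nitrogen. Among the compounds with values here, no measured step touches this position; the only recorded step concerns the carbonyl substituent, so it does not bear on the change here. The expectation for compound 3 in this assay is therefore a 1.0-fold lower number from compound 2 to compound 3 (0.01 log units; within the scatter), with wide uncertainty. Estimated: 150 nM, range 40 nM to 600 nM.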

Compound 3, inhibition constant: 440 nM
The estimate for compound 3 lay 2.9-fold (0.47 log units) below the measured number; low and high end bracket the measured number.
By their numbers in this assay, from the lowest: compound 1; then compound 2; then compound 3.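

In this assay, the amine side chain also affects the read-out: with the butylamide held constant, (diethylamino)methyl in place of phenyl on a saturated chain carbon bound to an amine nitrogen gives a 2.9-fold higher number from compound 2 to compound 3 (0.46 log units; beyond the scatter) on this series. The change removes a six-membered aromatic ring of carbon only and brings in an open chain carrying a hydrogen-bond acceptor. No measured evidence bears on this step.

Open, on these data alone, is whether the ring's removal or the diethylamino nitrogen's entry drives the change; cyclohexyl or pyridyl in place of phenyl would separate the two. Also open, as far as these compounds go, is whether the 2-(diethylamino)ethyl side chain behaves alike with the pentan-3-yl ester of compound 1.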